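The source may report more compounds than this note shows. Statements on the series, on what has been measured and on what is new or still open speak of the compounds shown alone.

The measured compounds, with their values in a functional assay on HepG2 cells (Homo sapiens) for cytotoxicity, read by MTT assay, with a stated time of 72 h; on this read-out higher numbers stand for weaker inhibition and lower numbers for stronger inhibition:

compound 1, `Cc1cc(=O)n(-c2cccc(F)c2)nc1C(=O)Nc1ccc(Oc2ncnc3[nH]ccc23)cc1`, gives 3180 nM
compound 2, `Cc1cc(=O)n(-c2ccccc2OC(F)(F)F)nc1C(=O)Nc1ccc(Oc2ncnc3[nH]ccc23)cc1`, gives 22800 nM
compound 3, `Cc1cc(=O)n(-c2ccc(Br)cc2F)nc1C(=O)Nc1ccc(Oc2ncnc3[nH]ccc23)cc1`, gives 3660 nM

All three share one core and differ only in the aryl group carried on an aromatic nitrogen. Compound 3 stands second highest of the three numbers: close to compound 1, with a 1.2-fold higher number from compound 1 to compound 3 (0.06 log units; within the scatter), and far from compound 2, with a 6.2-fold lower number from compound 2 to compound 3 (0.79 log units; beyond the scatter). The remaining step is a 7.2-fold higher number from compound 1 to compound 2 (0.86 log units; beyond the scatter), the only one of the three that lies beyond the scatter.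

Compound 4, `Cc1cc(=O)n(-c2cccc(C(F)(F)F)c2)nc1C(=O)Nc1ccc(Oc2ncnc3[nH]ccc23)cc1`, is not yet measured. It differs from compound 3 in one place: 3-(trifluoromethyl)phenyl in place of 4-bromo-2-fluorophenyl on an aromatic nitrogen. The steps from compound 1 to compound 3 and from compound 2 to compound 3 bear on this change, since each also exchanges one aryl group for another on the same nitrogen. Two of the three aryl groups tested gave numbers within the scatter of each other, and only 2-(trifluoromethoxy)phenyl moved the number further. Within the data shown here, with no measured step that points to a large shift for a further aryl exchange, in this assay the step from compound 3 to compound 4 is expected to be a 1.2-fold lower number from compound 3 to compound 4 (0.09 log units; within the scatter), within the scatter. Compound 4 is therefore estimated at 3000 nM, with a range from 1000 nM to 9000 nM.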

Compound 4, half-maximal inhibitory concentration: 9470 nM
Compound 4: the middle estimate sits 3.2-fold (0.50 log units) below what was measured, and the stated range ends below it.
By their numbers in this assay, from the lowest: compounds 1 and 3 (each within the scatter of the next); then compound 4; then compound 2.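

In this assay, among these compounds, the earlier compounds left 2-(trifluoromethoxy)phenyl as the only aryl group on this nitrogen that moved the number beyond the scatter, but 3-(trifluoromethyl)phenyl now does so as well, in the same direction (a 2.6-fold higher number from compound 3 to compound 4 (0.41 log units; beyond the scatter)). The closest comparison is with compound 1, where the only difference is trifluoromethyl in place of fluoro on an aromatic carbon of the aryl group, and this small exchange alone raises the number (a 3.0-fold higher number from compound 1 to compound 4 (0.47 log units; beyond the scatter)). Compound 4 does not reach the level of compound 2, however (a 2.4-fold lower number from compound 2 to compound 4 (0.38 log units; beyond the scatter)), so the four aryl groups fall into three levels rather than two: compounds 1 and 3 together, then compound 4, then compound 2.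

Nothing measured here explains why these aryl groups differ. Also open, on these data alone, is how the number would respond to a plain unsubstituted phenyl, or to an aryl group carrying an amine or a carboxylic acid in place of the halogens and fluorinated groups seen so far.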